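The compounds below may be only part of what the source reports. "The series", "measured", "known", "first", "only" and "open" are said of these compounds alone.

Working notes on a small set of hydroxamic acids tested in an assay on isolated protein for inhibition of protein deacetylase HDAC6 (Homo sapiens); a lower number here means a stronger inhibitor, a higher number a weaker inhibitor.

Compound 2, `COc1ccc(C(=O)c2ccc3c(ccn3Cc3ccc(C(=O)NO)cc3)c2)cc1`, gives 3.92 nM. Compound 1, `COc1ccc(C(=O)c2ccc3c(ccn3Cc3ccc(C(=O)NO)cc3)c2)cc1OC`, gives 15.5 nM. The difference between the two is methoxy in place of hydrogen on an aromatic carbon and the step is a 4.0-fold higher number from compound 2 to compound 1 (0.60 log units; beyond the scatter).

Compound 3, `COc1ccc(C(=O)c2ccc3c(ccn3S(=O)(=O)c3cccc(/C=C/C(=O)NO)c3)c2)cc1`, gives 751 nM. It carries a different core from compound 2; the difference between the two cores is not broken down here, and the two values alone show that compound 3 stands well above both compound 1 and compound 2 in this assay.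

Compound 4, `COc1ccc(C(=O)c2ccc3c(ccn3S(=O)(=O)c3cccc(/C=C/C(=O)NO)c3)c2)cc1OC`, is not yet measured. Relative to compound 3 the difference is methoxy in place of hydrogen on an aromatic carbon. For the measured compounds named here, this is the same change as that from compound 2 to compound 1, and on the same ring position, so the earlier step is the only guide. On that basis the step is expected to be a 3.3-fold higher number from compound 3 to compound 4 (0.52 log units; beyond the scatter), a weakening of about the size seen before, because the shift from compound 2 to compound 1 was a 4.0-fold higher number from compound 2 to compound 1 (0.60 log units; beyond the scatter). The estimate for compound 4 in this assay is therefore 2500 nM, with a range from 900 nM to 7000 nM, pending measurement.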

Compound 4, half-maximal inhibitory concentration: 1180 nM
Compound 4: middle estimate off by 2.1-fold (0.33 log units), on the high side; measured number inside the range.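

In this assay, going from 4-methoxyphenyl to 3,4-dimethoxyphenyl on the core of compound 3 gives a 1.6-fold higher number from compound 3 to compound 4 (0.20 log units; within the scatter), so on this core the added methoxy has no effect that can be told from the scatter. Set beside the step on the core of compound 2, the two results do not differ by more than the scatter allows: the same change on two cores in this assay, a 4.0-fold higher number (0.60 log units; beyond the scatter) from compound 2 to compound 1 and a 1.6-fold higher number (0.20 log units; within the scatter) from compound 3 to compound 4, 2.5-fold (0.40 log units) apart, within the scatter of two such steps This is compatible with the change carrying over from one core to the other, but it does not establish a shared step size or show that the core alters the step, as there are only two matched pairs, with one step beyond the scatter and one within it.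

The compounds shown leave open whether a hydroxyl, an amine or a longer chain such as ethoxy in place of the added methoxy would follow the same course on both cores. They also leave open which part of the difference between the two cores, if either matters at all, bears on the size of this step.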